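Methylating the Triazole: What Compound 4 Might Show

The source may hold more compounds than are shown below. What is called first, only, known or untested is meant among the compounds shown, and "the series" means these compounds.

Compound 1 `CC(C)(N)CC(=O)N[C@@H]1CCc2ccccc2N(Cc2ccc(-c3ccccc3-c3ncno3)cc2)C1=O` gives 30 nM in a functional assay (Pituitary gland cell) with Rattus norvegicus as the target; on this read-out higher numbers stand for an effect only at larger amounts of compound and lower numbers for an effect already at smaller amounts. Compound 2 `Cc1noc(-c2ccccc2-c2ccc(CN3C(=O)[C@H](NC(=O)CC(C)(C)N)CCc4ccccc43)cc2)n1` gives 1050 nM. Compound 3 `CC(C)(N)CC(=O)N[C@@H]1CCc2ccccc2N(Cc2ccc(-c3ccccc3-c3nc[nH]n3)cc2)C1=O` gives 90 nM.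

Compound 3 stands second highest of the three: the step of a 3.0-fold higher number from compound 1 to compound 3 (0.48 log units; beyond the scatter) is modest, while the step of a 12-fold lower number from compound 2 to compound 3 (1.07 log units; beyond the scatter) is large. Compound 4 `Cn1ncnc1-c1ccccc1-c1ccc(CN2C(=O)[C@H](NC(=O)CC(C)(C)N)CCc3ccccc32)cc1` differs from compound 3 by 1-methyl-1H-1,2,4-triazol-5-yl in place of 1H-1,2,4-triazol-3-yl on an aromatic carbon, so the ring keeps its atoms but gains a methyl on nitrogen and loses its hydrogen-bond donor. The step that bears on this is a 35-fold higher number from compound 1 to compound 2 (1.54 log units; beyond the scatter), where adding a methyl to a ring in this same region raised the number sharply. A rise is therefore expected for compound 4, roughly a 6.7-fold higher number from compound 3 to compound 4 (0.82 log units; beyond the scatter). Compound 4 is estimated at 600 nM, with a range from 150 nM to 3000 nM.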

Compound 4, half-maximal effective concentration: 265 nM
For compound 4 the middle estimate is 2.3-fold (0.35 log units) above the measured one, and the stated range covers the measured number.
By their numbers in this assay, from the lowest: compound 1; then compound 3; then compound 4; then compound 2.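

Moving from the 1H-1,2,4-triazol-3-yl to the 1-methyl-1H-1,2,4-triazol-5-yl, which adds a methyl and has no hydrogen-bond donor, gives only a 2.9-fold higher number from compound 3 to compound 4 (0.47 log units; beyond the scatter) and so is a milder change than the large 35-fold higher number from compound 1 to compound 2 (1.54 log units; beyond the scatter) seen with the methylated oxadiazole. The two methylated rings are not interchangeable at this place, with a 4.0-fold lower number from compound 2 to compound 4 (0.60 log units; beyond the scatter) separating them. Even so, the methylated triazole does not match the oxadiazole without a methyl, as there is an 8.8-fold higher number from compound 1 to compound 4 (0.95 log units; beyond the scatter) between them.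

Nothing shown gives a reason for these differences. On these data alone, whether an amine or a carboxylic acid on the ring at this place would give a lower or higher number stays open.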